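Swapping a Dichlorophenyl Ring for a Chloropyridine Ring

A few compounds are considered here, and "the series" means these few. Any claim that something is new, unique, unknown or untested is made for them only; others in the source may bear on it.

In an ADME assay on A549 cells (Homo sapiens) for cytotoxicity, read by resazurin assay, with a stated time of 48 h (on this read-out lower numbers stand for higher toxicity in this test and higher numbers for lower toxicity in this test), compound 1 (`O=C(Nc1ccc(NCc2ccc(F)cc2)cc1Cl)c1cc(Cl)ccc1O`) gives 54400 nM and compound 2 (`O=C(Nc1ccc(NCc2cc(Cl)cc(Cl)c2)cc1Cl)c1cc(Cl)ccc1O`) gives 13300 nM as the lower of these two numbers. Compound 3 (`O=C(Nc1ccc(NCc2cccnc2Cl)cc1Cl)c1cc(Cl)ccc1O`) has 2-chloropyridin-3-yl in place of the 3,5-dichlorophenyl on a saturated chain carbon bound to a nitrogen on an aromatic ring (2-chloropyridin-3-yl in place of 3,5-dichlorophenyl on a saturated chain carbon bound to a nitrogen on an aromatic ring). Going by the values given here, one measured step bears on this, a change of group on that same carbon (a 4.1-fold lower number from compound 1 to compound 2 (0.61 log units; beyond the scatter)). It is modest but beyond the scatter, so groups at this place can shift the number. Among the compounds with values here, no measured compound has a ring with a hetero atom there, which leaves the direction uncertain. With compound 2 at 13300 nM as the lower of just two values, a modest move to a higher number is expected (a 2.3-fold higher number from compound 2 to compound 3 (0.35 log units; beyond the scatter)). Compound 3 is estimated at 30000 nM (expected range 11000 nM to 75000 nM).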

Compound 3, half-maximal cytotoxic concentration: 101000 nM
Compound 3: the middle estimate sits 3.4-fold (0.53 log units) below what was measured, and the stated range ends below it.
By their numbers in this assay, from the lowest: compound 2; then compounds 1 and 3 (each within the scatter of the next).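

In this assay, the carbon on the nitrogen now proves able to carry a ring with a hetero atom, and the number moves a long way up on this change (a 7.6-fold higher number from compound 2 to compound 3 (0.88 log units; beyond the scatter)). Against the 4-fluorophenyl group, the 2-chloropyridin-3-yl group gives no readable difference (a 1.9-fold higher number from compound 1 to compound 3 (0.27 log units; within the scatter)), so among these three compounds only compound 2, with its 3,5-dichlorophenyl group, stands apart.

On these data alone, this single swap changes the ring nitrogen, the number of chlorines and the place of the chlorine all at once, and three compounds cannot separate these changes, so how a 2-chlorophenyl ring or a pyridin-3-yl ring without chlorine would read remains open. Nothing measured here says why the number moves as it does.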